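From Hydroxy to Pentyloxy on an Ethyl Ester

This account rests on a few compounds, and the source may have more. Where it says the series, first, only, none or still open, it means among the compounds named here.

In a functional assay on the whole organism (strain Sprague-Dawley) for inhibition, with Rattus norvegicus as the target, with a stated time of 10 min (on this read-out lower numbers stand for an effect already at smaller amounts and higher numbers for an effect only at larger amounts of compound), compound 1 `O=C(O)c1cnc(-c2ccccc2O)[nH]c1=O` gives > 5 mg/kg as its reading, and this is a limit of the assay, not a number. For compound 2 `CCOc1ccc(S(=O)(=O)Cl)cc1-c1ncc(C(=O)O)c(=O)[nH]1` the entry is "not determined" (no result reported) and so it offers nothing to compare. Going by the values given here, compound 3 `CCOC(=O)c1cnc(-c2ccccc2O)[nH]c1=O` gives 5 mg/kg as the only true number so far, which leaves it with no firm value on either side.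

Compound 4 `CCCCCOc1ccccc1-c1ncc(C(=O)OCC)c(=O)[nH]1` differs from compound 3 in one place. The change pentyl in place of hydrogen on an oxygen on an aromatic ring puts pentyl in place of hydrogen on an oxygen on an aromatic ring, taking hydroxy to pentyloxy.

Among the compounds with values here, only one measured step bears on this, and only loosely. It is a number no higher from compound 1 to compound 3 (the limit leaves the size open) and it puts ethyl on the oxygen of the acid, not on the oxygen on the aromatic ring. Within the data shown here, its size cannot be read, so it suggests a direction at best, and no measured step touches the hydroxy itself. A modest move toward a lower number is therefore expected, with wide uncertainty. The expected change is a 2.5-fold lower number from compound 3 to compound 4 (0.40 log units; beyond the scatter) in this assay on this reasoning. For compound 4 the estimate is 2 mg/kg as the middle value, with an expected range from 0.5 mg/kg to 8 mg/kg around it.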

Compound 4, dose for 50% inhibition: 2 mg/kg
Compound 4: middle estimate and measured number agree at the digits printed, and the stated range covers the measured number.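

Going by these compounds alone, the change from hydroxy to pentyloxy gives a 2.5-fold lower number from compound 3 to compound 4 (0.40 log units; beyond the scatter) in this assay, and this is the first step whose size can be read. Within the data shown here, it is also the first step to fall on an oxygen on an aromatic ring, since the earlier one changed only the oxygen next to a carbonyl group. A free hydroxy at this place is therefore not needed for a measurable effect in this assay, as compound 4, with pentyl on that oxygen, reads lower than compound 3 by more than the scatter. The earlier step cannot be read for size, and the reading of compound 1 is a limit, not a number: the limit of > 5 mg/kg in this assay, at which 1 of the 4 values shown sits.

The compounds shown do not tell how a shorter chain such as methyl, a longer chain such as octyl, or an amine at the end of the chain would read on this oxygen. Going by these compounds, it also stays open whether pentyl on this oxygen would give a similar step with the free carboxylic acid of compound 1 in place of the ethyl ester.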